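This account rests on a few compounds, and the source may have more. Where it says the series, first, only, none or still open, it means among the compounds named here.

Working notes on the series.

Two members have numbers in a functional assay on MCF7 cells (Homo sapiens) for inhibition, read by MTT assay, with a stated time of 72 h; on this read-out lower numbers stand for stronger inhibition and higher numbers for weaker inhibition. Compound 1 `Cc1cc(Nc2cc(-c3ccccc3)[nH]n2)n2nc(SCCCc3ccccc3)nc2n1` gives 3900 nM in this assay. Compound 2 `Cc1nc2nc(SCc3ccc(Cl)cc3)nn2c(Nc2cc(-c3ccccc3)[nH]n2)c1C` gives 10600 nM in this assay. Compound 1 thus holds the lowest of the two numbers recorded, and the gap to its nearest neighbour, compound 2, lies beyond the scatter. For the measured compounds named here, compound 2 differs from compound 1 in more than one place, so no single step between them is counted.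

The next member, compound 3 `Cc1cc(Nc2cc(-c3ccccc3)[nH]n2)n2nc(SCC3CC3)nc2n1`, has not yet been measured in this assay. It departs from compound 1 by one change:

cyclopropyl in place of phenethyl on a saturated chain carbon bound to a sulfur

The group that leaves carries one six-membered aromatic ring of carbon only; the group that enters carries one three-membered non-aromatic ring of carbon only, at the same place on a saturated chain carbon bound to a sulfur.

Going by the values given here, no measured pair covers such a change, so the size of the step can only be expected, not read off. The step in this assay is expected to be a 1.7-fold higher number from compound 1 to compound 3 (0.22 log units; within the scatter), a move toward a higher number, of a size that may or may not clear the scatter. For compound 3 the estimated value in this assay is 6500 nM, with a range from 2500 nM to 17000 nM.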

Compound 3, half-maximal inhibitory concentration: > 50000 nM
Compound 3: a limit, no number; the forecaster's own chance of this, stated with the estimate: 10%; middle value at least 7.6-fold (0.88 log units) away from the limit.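

In this assay compound 3 gives > 50000 nM, which is a limit of the assay and not a number. For the compounds shown here, the replacement of phenethyl by cyclopropyl on a saturated chain carbon bound to a sulfur is the first change that can be read on its own, and it gives an at least 12-fold higher number from compound 1 to compound 3 (1.10 log units; beyond the scatter), so the read-out clearly responds to the group held at this place. This single step combines two differences, 8 heavy atoms against 3 and a six-membered aromatic ring of carbon against a three-membered non-aromatic ring of carbon, and its printed size is only a lower bound, with the full size out of reach: the limit of > 50000 nM in this assay, at which 1 of the 3 values shown sits.

The compounds shown do not separate the contribution of the aromatic ring from that of the size of the group, and with one step at this place no trend can be drawn. A cyclohexylethyl group, with a saturated ring in place of the aromatic one, or an unbranched hexyl chain with no ring at all, would be needed at this place to tell these two differences apart.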